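Replacing 4-methylpiperazin-1-yl with methoxy on a carbonyl carbon

This account rests on a few compounds, and the source may have more. Where it says the series, first, only, none or still open, it means among the compounds named here.

Compound 1 `CN1CCN(C(=O)/C=C/c2ccncc2-c2ccc3ccccc3c2)CC1` was tested in a functional assay on MDA-MB-231 cells (Homo sapiens) for inhibition, read by sulforhodamine B assay, with a stated time of 72 h (a higher number here means a weaker inhibitor of growth, a lower number a stronger inhibitor of growth), and gives > 10000 nM there, which is a limit of the assay and not a number. Compound 2 `CCOC(=O)/C=C/c1ccncc1-c1ccc2[nH]ccc2c1` gives > 10000 nM as well, again only a limit. Compound 1 thus shares the limit of > 10000 nM in this assay, at which 2 of the 3 values shown sit, and no exact potency can be read for it. Compound 3 `CCOC(=O)/C=C/c1ccncc1-c1ccc2cc[nH]c2c1` alone gives a true number of 7980 nM here.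

Compound 4 `COC(=O)/C=C/c1ccncc1-c1ccc2ccccc2c1` keeps the core of compound 1 but carries methoxy in place of 4-methylpiperazin-1-yl on a carbonyl carbon and has not yet been measured. That makes it an ester, as compounds 2 and 3 are, although their cores differ. Within the data shown here, no measured step shows what such a swap does, so the size of the change in this assay can only be guessed. Compound 3 gives 7980 nM as an ester, which points to a modest move toward stronger inhibition. Compound 2 goes against this: as an ester it gives > 10000 nM and so only a limit. The expected step is an at least 1.4-fold lower number from compound 1 to compound 4 (0.15 log units; that floor lies within the scatter) and the result may still end at the limit. In this assay compound 4 is estimated to give 7000 nM with a range (2500 nM to 20000 nM) expected.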

Compound 4, concentration for 50% growth inhibition: 4710 nM
Estimate against measurement, compound 4: 1.5-fold (0.17 log units) above; measured number inside the range.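

Among these compounds, this is the first measured step at this place: methoxy in place of 4-methylpiperazin-1-yl on a carbonyl carbon gives an at least 2.1-fold lower number from compound 1 to compound 4 (0.32 log units; beyond the scatter) in this assay. With the core of compound 1 held fixed, the group on this carbonyl carbon therefore makes a real difference to growth inhibition, and the ester compound 4 gives a true number where the amide compound 1 does not. The size of the step is only a minimum, and the real gap may be larger, because compound 1 stands at a limit of the assay rather than at a number: the limit of > 10000 nM in this assay, at which 2 of the 4 values shown sit.

This single step does not separate the effect of losing the 4-methylpiperazin-1-yl ring from the effect of changing an amide into an ester, and compounds 2 and 3 cannot settle this since their cores differ from that of compound 4. A carboxylic acid or a small dimethylamino amide on the same carbonyl carbon would show whether the ester itself matters or whether other small groups serve as well.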